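Swapping a tert-butyl for fluoro in a paw edema test

The source may report more compounds than this note shows. Statements on the series, on what has been measured and on what is new or still open speak of the compounds shown alone.

Measured so far:
compound 1 `Cc1cc(O)ccc1C1=NN(c2ccc(S(C)(=O)=O)cc2)C(=O)CC1`: 52.6%
compound 2 `CC(C)(C)c1ccc(C2=NN(c3ccc(S(C)(=O)=O)cc3)C(=O)CC2)cc1`: 68.4%

Of the compounds shown here, two sharing the same core have been tested in a functional assay on the whole organism (strain Wistar) for inhibition, with Rattus norvegicus as the target, read by paw edema, with stated times of 30 min and 5 h, at a dose of 0.05 mmol/kg by the oral route; a lower number here means less inhibition, a higher number more inhibition at the dose given (going by the name of the read-out). Compound 1 `Cc1cc(O)ccc1C1=NN(c2ccc(S(C)(=O)=O)cc2)C(=O)CC1` gives 52.6% in this assay, and compound 2 `CC(C)(C)c1ccc(C2=NN(c3ccc(S(C)(=O)=O)cc3)C(=O)CC2)cc1` gives 68.4%. Of the two numbers, compound 2 stands highest, and its gap to compound 1 lies beyond the usual scatter, so the two differ in more than chance would allow. They differ, however, in more than one place, so no single change can be read off from the pair.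

Compound 3 `CS(=O)(=O)c1ccc(N2N=C(c3ccc(F)cc3)CCC2=O)cc1` has not yet been measured. It is reached from compound 2 by one change: fluoro in place of tert-butyl on an aromatic carbon. Among the compounds with values here, no measured pair shows this exact swap, so its effect is open. Since the incoming group is far smaller than the one it replaces, a moderate downward step in this assay is expected, though one that may not clearly exceed the scatter; the expected step from compound 2 to compound 3 is a number 11.4 percentage points lower from compound 2 to compound 3 (beyond the scatter). Compound 3 is therefore estimated at 57%, within a range from 38% to 74%.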

Compound 3, a percentage reported as inhibition, in the whole organism at one dose (the size of the read-out at that dose, not a potency): 73.6%
Estimate against measurement, compound 3: 16.6 percentage points below, and the stated range covers the measured number.
By their numbers in this assay, from the lowest: compound 1; then compounds 2 and 3 (each within the scatter of the next).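

On the aromatic carbon para to a large group, fluoro in place of tert-butyl gives a number 5.2 percentage points higher from compound 2 to compound 3 (within the scatter) in this assay, so a single fluorine atom and a four-carbon tert-butyl cannot be told apart at this position in this test, at this one dose. The change of 4-hydroxy-2-methylphenyl to 4-fluorophenyl on the carbon with a double bond to nitrogen gives a number 21 percentage points higher from compound 1 to compound 3 (beyond the scatter) and, unlike the tert-butyl swap, is a difference larger than repeat measurements would produce, although it alters the hydroxy and methyl groups together. Nothing at hand explains either step.

The compounds shown leave open whether an amine, a carboxylic acid or a longer carbon chain on the same aromatic carbon would also keep the reading in this assay where compound 2 and compound 3 stand. They also leave open whether the hydroxy group or the methyl group of compound 1 accounts for its step, as neither is changed on its own here.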